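Trimethoxy styryl sulfones: dropping one methoxy

The compounds below may be only part of what the source reports. "The series", "measured", "known", "first", "only" and "open" are said of these compounds alone.

Compound 1 `COc1cc(OC)c(/C=C/S(=O)(=O)Cc2ccc(OC)c(N)c2)c(OC)c1` gives in a functional assay on MCF7 cells (Homo sapiens) for cytotoxicity, read by MTT assay, with a stated time of 72 h (a lower number here means a stronger inhibitor of growth, a higher number a weaker inhibitor of growth), a reading that is a limit of the assay, < 10 nM. Compound 2 `COc1cc(OC)c(/C=C/[S+]([O-])Cc2ccc(OC)c(N)c2)c(OC)c1` likewise sits at a limit, < 10 nM. Compound 3 `COc1cc(OC)c(NC(=O)CS(=O)(=O)Cc2ccc(OC)c([N+](=O)[O-])c2)c(OC)c1` reaches only a limit in the opposite direction, > 30000 nM. For the measured compounds named here, compound 1 therefore stands with compound 2 at the limit of < 10 nM in this assay, at which 2 of the 3 values shown sit, while compound 3 sits at the limit of > 30000 nM in this assay, at which 1 of the 3 values shown sits; no step between measured compounds is defined, so no measured change of known size is available for comparison. Compound 4 `COc1ccc(CS(=O)(=O)/C=C/c2c(OC)cccc2OC)cc1N` differs from compound 1 by hydrogen in place of methoxy on an aromatic carbon, on the carbon para to a large group. In this assay the step is expected to weaken inhibition by a moderate amount beyond the scatter, an at least 5.0-fold higher number from compound 1 to compound 4 (0.69 log units; beyond the scatter), with some chance of a limit only. Compound 4 is estimated at 50 nM, within 8 nM to 400 nM.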

Compound 4, concentration for 50% growth inhibition: 40 nM
Beside the measured number, compound 4's estimate is 1.3-fold (0.10 log units) above it; the range from low to high includes it.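

In this assay, for the compounds shown here, the methoxy para to a large group proves to matter: replacing it with hydrogen gives the first measured step, an at least 4.0-fold higher number from compound 1 to compound 4 (0.60 log units; beyond the scatter). Going by these compounds alone, compound 4 also gives a number rather than a limit, 40 nM, so this analogue is the first that can anchor later steps at this carbon. Compound 1 is a limit, so the full size of the step stays open: the limit of < 10 nM in this assay, at which 2 of the 4 values shown sit.

A hydroxyl, a fluorine or an ethoxy on this carbon would show whether methoxy itself is needed. On these data alone, whether the same change has a similar effect on compound 2 also remains open.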